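The source may report more compounds than this note shows. Statements on the series, on what has been measured and on what is new or still open speak of the compounds shown alone.

Measured compounds:
- compound 1, `CNC(=O)c1cnc(N2CCN(C3CCN(Cc4ccc(Cl)cc4)CC3)[C@@H](C)C2)c(Cl)c1`, 32 nM
- compound 2, `C[C@@H]1CN(C2CCN(Cc3ccc(Cl)cc3)CC2)CCN1c1ncc(C(=O)NCc2ccc(Cl)c(Cl)c2)cc1Cl`, 220 nM
- compound 3, `CC(=O)Nc1cnc(N2CCN(C3CCN(Cc4ccc(Cl)cc4)CC3)[C@@H](C)C2)c(Cl)c1`, 8 nM

In a functional assay for antagonist activity at C-X-C chemokine receptor type 3 (Homo sapiens) (on this read-out higher numbers stand for weaker inhibition and lower numbers for stronger inhibition), compound 3 gives the lowest number of the three. The nearest is compound 1, and the step of a 4.0-fold lower number from compound 1 to compound 3 (0.60 log units; beyond the scatter) is beyond the scatter. Among the compounds with values here, compound 2, which carries a dichlorobenzyl amide where compound 1 carries a methyl amide, gives a higher number again, though no single step connects it to compound 3.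

Compound 4, `C[C@H]1CN(c2ncc(C(=O)N3CCCCC3)cc2Cl)CCN1C1CCN(Cc2ccc(Cl)cc2)CC1`, differs from compound 3 in one place: (piperidin-1-yl)carbonyl in place of acetamido on an aromatic carbon. Within the data shown here, no measured step covers this exact change. What is known is that an acetamido at this position does better than a methyl amide, and that the larger amide of compound 2 sits above both. A tertiary piperidine amide with no hydrogen-bond donor is therefore expected to move the number upward, probably by more than the step from compound 1 to compound 3 but less than the gap to compound 2. The estimate for compound 4 in this assay is 100 nM, with a range from 30 nM to 400 nM, meaning an expected step of a 13-fold higher number from compound 3 to compound 4 (1.10 log units; beyond the scatter).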

Compound 4, half-maximal inhibitory concentration: 900 nM
Beside the measured number, compound 4's estimate is 9.0-fold (0.95 log units) below it; the whole stated range lies below it.
By their numbers in this assay, from the lowest: compound 3; then compound 1; then compound 2; then compound 4.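

In this assay, replacing the smaller groups at this position with the tertiary piperidine amide gives much larger steps, a 110-fold higher number from compound 3 to compound 4 (2.05 log units; beyond the scatter) and a 28-fold higher number from compound 1 to compound 4 (1.45 log units; beyond the scatter), than the exchange between those smaller groups, a 4.0-fold lower number from compound 1 to compound 3 (0.60 log units; beyond the scatter). Size alone does not set the order: compound 4 gives the highest number of the series, although compound 2, at 220 nM, carries the larger dichlorobenzyl amide, while the (piperidin-1-yl)carbonyl group of compound 4 has 0 hydrogen-bond donors. Nothing available explains why the number rises so far with this change.

From the compounds shown here alone, it remains open whether the missing amide hydrogen or the ring matters more, a question that a dimethylamide or an N-cyclohexyl amide at this position could separate. Going by these compounds, how a carboxylic acid or an aminomethyl group would behave at the same position also remains unknown.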